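Five-membered heteroaryl on the aromatic carbon: oxazole step

This account rests on a few compounds, and the source may have more. Where it says the series, first, only, none or still open, it means among the compounds named here.

Measured so far:
compound 1 `Cn1nccc1-c1cccc2c1CCC2c1ncc[nH]1`: 58%
compound 2 `c1ccc2c(c1)CCC2c1ncc[nH]1`: 54%

In a functional assay on CHO cells for agonist activity at Alpha-1A adrenergic receptor (Homo sapiens), read by FLIPR and calcium flux (on this read-out lower numbers stand for smaller maximal responses and higher numbers for larger maximal responses), compound 1 gives 58% and compound 2 gives 54%. Compound 2 sits alongside compound 1 on this read-out; the step of a number 4 percentage points lower from compound 1 to compound 2 (within the scatter) falls within the scatter, so the two numbers are not told apart here.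

Compound 3 `c1cc(-c2ncco2)c2c(c1)C(c1ncc[nH]1)CC2` differs from compound 2 by 1,3-oxazol-2-yl in place of hydrogen on an aromatic carbon. Going by the values given here, the one measured step that bears on this exchange is the one between compound 1 and compound 2, where a five-membered aromatic ring with hetero atoms stood on an aromatic carbon in place of hydrogen, and that step, a number 4 percentage points lower from compound 1 to compound 2 (within the scatter), stayed within the scatter. On this basis a step of a number 2 percentage points higher from compound 2 to compound 3 (within the scatter) is expected from compound 2 to compound 3, that is, no change beyond the scatter. For compound 3 the estimate in this assay is 56%, with a range of 40% to 72%.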

Compound 3, largest response reached (Emax), in percent of the reference or control that the assay uses: 63%
Beside the measured number, compound 3's estimate is 7 percentage points below it; low and high end bracket the measured number.
By their numbers in this assay, from the lowest: compounds 2, 1 and 3 (each within the scatter of the next).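

In this assay, 1,3-oxazol-2-yl in place of hydrogen on an aromatic carbon gives a number 9 percentage points higher from compound 2 to compound 3 (within the scatter), so this second five-membered aromatic ring with hetero atoms, like the first, is not told apart from hydrogen at this position. The exchange of one ring for the other, 1,3-oxazol-2-yl in place of 1-methyl-1H-pyrazol-5-yl, gives a number 5 percentage points higher from compound 1 to compound 3 (within the scatter), which shows that the two rings are not told apart from each other either, so hydrogen and both rings now read alike on this aromatic carbon. No supporting data bear on this result.

Open, as far as these compounds go, is whether a group of another kind on this aromatic carbon, such as an amine, a carboxylic acid or a longer alkyl chain, would move the maximal response beyond the scatter. Also open, from the compounds shown here alone, is how 1,3-oxazol-2-yl would read on another aromatic carbon of the shared core.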